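Working notes: adding bromo to compound 2

A few compounds are considered here, and "the series" means these few. Any claim that something is new, unique, unknown or untested is made for them only; others in the source may bear on it.

Compound 1 `CC(=O)N1N=C(c2ccccc2)CC1c1ccc(N(C)C)cc1`: 12000 nM
Compound 2 `CC(=O)N1N=C(c2ccccc2)CC1c1cccc(Cl)c1Cl`: 36800 nM

Both compounds were measured in a functional assay on OVCAR cells (Homo sapiens) for cytotoxicity, read by sulforhodamine B assay, with a stated time of 48 h; a lower number here means a stronger inhibitor, a higher number a weaker inhibitor. Compound 2 stands at the higher number of the two, which makes it the weaker inhibitor, and its gap to compound 1 lies beyond the scatter.

The next entry is compound 3 `CC(=O)N1N=C(c2ccc(Br)cc2)CC1c1cccc(Cl)c1Cl`, which keeps the dichlorophenyl side of compound 2 and changes the other aromatic ring from phenyl to 4-bromophenyl. The counted difference is bromo in place of hydrogen on an aromatic carbon. Going by the values given here, no measured pair shows this change, so there is little to anchor the expectation.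

A modest step toward a lower number in this assay is expected, and the estimated step is a 1.7-fold lower number from compound 2 to compound 3 (0.22 log units; within the scatter). Compound 3 is expected at 22000 nM, with an estimated range from 8000 nM to 55000 nM.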

Compound 3, half-maximal inhibitory concentration: 39800 nM
Compound 3: the middle estimate sits 1.8-fold (0.26 log units) below what was measured; low and high end bracket the measured number.
By their numbers in this assay, from the lowest: compound 1; then compounds 2 and 3 (each within the scatter of the next).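

In this assay, bromo in place of hydrogen on an aromatic carbon, para to a large group, gives a 1.1-fold higher number from compound 2 to compound 3 (0.03 log units; within the scatter) with the dichlorophenyl side held fixed. Going by these compounds alone, this is the first step that isolates one place, and it shows that this position accepts one added bromine atom with the two numbers staying within the scatter, although this rests on a single pair. Nothing measured on hand explains this result.

The compounds shown leave open whether a different group at this position, such as an amine, a carboxylic acid or a longer chain, would move the number beyond the scatter. Also open, going by these compounds, is whether bromo on the same ring gives a like step on compound 1, whose other aromatic ring differs.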